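Aryl ether series: ethoxy to methoxy step

The compounds below may be only part of what the source reports. "The series", "measured", "known", "first", "only" and "open" are said of these compounds alone.

Compound 1 `CCOc1ccc(C2CC2C(=O)NNC(=O)c2ccncc2)cc1`: in a functional assay on PC-3 cells (Homo sapiens) for inhibition, read by MTT assay, with a stated time of 72 h (on this read-out lower numbers stand for stronger inhibition and higher numbers for weaker inhibition), compound 1 gives > 100000 nM, a limit of the assay and not a number.
Compound 2 `O=C(NNc1nncc2ccccc12)C1CC1c1ccc(OC(F)(F)F)cc1`: in this assay compound 2 gives 92000 nM.

Compound 1 stands at the limit, (the limit of > 100000 nM in this assay, at which 1 of the 2 values shown sits); compound 2 gives a number at the weak end. Within the data shown here, no step between measured compounds is known for the change to compound 3 `COc1ccc(C2CC2C(=O)NNC(=O)c2ccncc2)cc1`, which differs from compound 1 by hydrogen in place of methyl on a saturated chain carbon bound to an oxygen on an aromatic ring. A step of this kind is expected to stay within the scatter, in no set direction. Compound 3 is therefore estimated at 100000 nM, between 40000 nM and 300000 nM. The expected step of a number no higher from compound 1 to compound 3 (the limit leaves the size open) is small.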

Compound 3, half-maximal inhibitory concentration: > 100000 nM
Compound 3 was reported as a limit; the forecaster's own chance of this, stated with the estimate: 60%; the middle value lies on the limit itself.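

Compound 1 and compound 3 are both reported as limits and not as numbers, so no step can be read between them: the limit of > 100000 nM in this assay, at which 2 of the 3 values shown sit.

Going by these compounds, the size and direction of the ethoxy to methoxy change in this assay stay open.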